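Extending the acid on the piperidine of compound 2

A few compounds are considered here, and "the series" means these few. Any claim that something is new, unique, unknown or untested is made for them only; others in the source may bear on it.

Compound 2 `CC(C)(C)N1C[C@@H](C(=O)Nc2nccn2Cc2ccccc2N2CCC(C(=O)O)CC2)[C@H](c2ccc(F)cc2F)C1` gives 460 nM in a functional assay for agonist activity at Melanocyte-stimulating hormone receptor (Homo sapiens), read by cAMP accumulation; a higher number here means that more compound is needed for the effect, a lower number that less compound is needed. Compound 1 `CC(C)(C)N1C[C@@H](C(=O)Nc2nccn2Cc2ccccc2-c2ccccc2)[C@H](c2ccc(F)cc2F)C1` gives 527 nM. These two values lie within the scatter of each other, so on the numbers shown compound 2 cannot be ordered against compound 1. For the measured compounds named here, the step of a 1.1-fold lower number from compound 1 to compound 2 (0.06 log units; within the scatter) is the only measured change, and it exchanged phenyl for 4-carboxypiperidin-1-yl without moving the number beyond the scatter. Compound 3 `CC(C)(C)N1C[C@@H](C(=O)Nc2nccn2Cc2ccccc2N2CCC(CC(=O)O)CC2)[C@H](c2ccc(F)cc2F)C1` differs from compound 2 by carboxymethyl in place of carboxy on a saturated ring carbon. Going by the values given here, no measured step touches this change directly; the one step that exists stays within the scatter, which gives no reason to expect a move in this assay beyond the scatter in either direction. Compound 3 is therefore expected to give about 460 nM, between 150 nM and 1400 nM, which means an estimated step of no change at the digits printed from compound 2 to compound 3 (within the scatter) that is expected to stay within the scatter.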

Compound 3, half-maximal effective concentration: 1980 nM
Compound 3: middle estimate off by 4.3-fold (0.63 log units), on the low side, and the stated range ends below it.
By their numbers in this assay, from the lowest: compounds 2 and 1 (each within the scatter of the next); then compound 3.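

In this assay, the saturated ring carbon carrying the acid responds to a small change: going from carboxy to carboxymethyl raises the group from 3 to 4 heavy atoms and gives a 4.3-fold higher number from compound 2 to compound 3 (0.63 log units; beyond the scatter). The earlier exchange of phenyl for 4-carboxypiperidin-1-yl stayed within the scatter, but that result does not extend to every piperidine acid, since 4-(carboxymethyl)piperidin-1-yl in the same place gives a 3.8-fold higher number from compound 1 to compound 3 (0.57 log units; beyond the scatter). Carboxy and carboxymethyl have the same hydrogen-bond donor and acceptor counts. Compound 3 still has a higher number than compound 2.

Still open, on these data alone, is whether a longer chain carrying the acid would raise the number further, and whether an amine or a primary amide on the same ring carbon would match carboxy or carboxymethyl. Nothing measured here explains the step.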